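The compounds below may be only part of what the source reports. "The series", "measured", "known", "first", "only" and "open" are said of these compounds alone.

Working notes on a short series of anilino-pyrimidine analogues. Compound 1 `Cc1ccccc1Nc1nc(Nc2ccc(N3CCCCC3)cc2)ncc1Cl` and compound 2 `CN1CCN(c2ccc(Nc3ncc(Cl)c(NCc4ccc(C(F)(F)F)cc4)n3)nc2)CC1` have both been run in an ADME assay on L02 cells (Homo sapiens) for inhibition, read by CCK-8 assay, with a stated time of 48 h; a higher number here means a weaker inhibitor of growth, a lower number a stronger inhibitor of growth. Compound 1 gives 5690 nM. Compound 2 gives 26200 nM, the higher of the two numbers, and its gap to compound 1 is beyond the scatter, so compound 2 is the weaker growth inhibitor of the pair. Compound 3 `CN1CCN(c2ccc(Nc3ncc(Cl)c(Nc4ccc(C(C)(C)C)cc4)n3)nc2)CC1` is not yet measured. Compound 3 differs from compound 2 in one place: 4-(tert-butyl)phenyl in place of 4-(trifluoromethyl)benzyl on a nitrogen on an aromatic ring. For the measured compounds named here, no measured pair tells directly what this change does. Going by the values given here, since compound 1, the only other member, sits at 5690 nM, the expectation is a step from compound 2 to compound 3 of a 2.9-fold lower number from compound 2 to compound 3 (0.46 log units; beyond the scatter), toward a lower number and beyond the scatter. Compound 3 is therefore estimated to give 9000 nM in this assay, within a range of 3000 nM to 27000 nM.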

Compound 3, concentration for 50% growth inhibition: 6070 nM
Beside the measured number, compound 3's estimate is 1.5-fold (0.17 log units) above it; low and high end bracket the measured number.
By their numbers in this assay, from the lowest: compounds 1 and 3 (each within the scatter of the next); then compound 2.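

In this assay, for the compounds shown here, 4-(tert-butyl)phenyl in place of 4-(trifluoromethyl)benzyl on a nitrogen on an aromatic ring gives a 4.3-fold lower number from compound 2 to compound 3 (0.64 log units; beyond the scatter) and is the first measured step at this position, with the rest of compound 2 unchanged. The exchange replaces 11 heavy atoms (8 carbon, 3 fluorine) with 10 carbon, while both groups have one six-membered aromatic ring of carbon only, no hydrogen-bond donors or acceptors, and no net charge. No measurement available here accounts for the step.

Benzyl gives way to phenyl and trifluoromethyl to tert-butyl in the same step, and the compounds shown do not separate the two changes. Open questions are how 4-(trifluoromethyl)phenyl or 4-(tert-butyl)benzyl would read on this nitrogen, and whether a phenyl ring carrying an amine or a carboxylic acid would fit the same trend.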